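Removing a Methyl Group in a Benzoxazole Series

This account rests on a few compounds, and the source may have more. Where it says the series, first, only, none or still open, it means among the compounds named here.

Measured so far in a functional assay on HT-29 cells (Homo sapiens) for cytotoxicity, read by MTT assay, with a stated time of 24 h; a higher number here means a weaker inhibitor, a lower number a stronger inhibitor:
compound 1 `Cc1ccc2oc(-c3ccc(NC(=O)CN4CCN(CCN(C)C)CC4)c(C)c3)nc2c1`: 7240 nM
compound 2 `Cc1cc(-c2nc3ccccc3o2)ccc1NC(=O)CN1CCN(CCN(C)C)CC1`: 12900 nM
compound 3 `Cc1cc(-c2nc3ccccc3o2)ccc1NC(=O)CN1CCN(CCCN(C)C)CC1`: 15500 nM

Compound 1 and compound 2 differ in one place, (hydrogen in place of methyl on an aromatic carbon), and that change gave a 1.8-fold higher number from compound 1 to compound 2 (0.25 log units; within the scatter). Compound 2 and compound 3 differ in a different place and show a 1.2-fold higher number from compound 2 to compound 3 (0.08 log units; within the scatter). Compound 3 and compound 1 share the same atoms joined differently; the difference between the two cores is not broken down here.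

Compound 4 `CN(C)CCCN1CCN(CC(=O)Nc2ccc(-c3nc4ccccc4o3)cc2)CC1` has not yet been measured. It differs from compound 3 by hydrogen in place of methyl on an aromatic carbon. Among the compounds with values here, this is the same kind of change as the one from compound 1 to compound 2, but the surroundings are not the same: in compound 1 the methyl sits on a ring that is part of a fused or bridged system of two rings, meta to a fused ring and para to a fused ring, whereas in compound 3 it sits ortho to a large group and meta to a 1,3-benzoxazol-2-yl group. The expected step is a 1.3-fold higher number from compound 3 to compound 4 (0.11 log units; within the scatter), resting on the earlier 1.8-fold higher number from compound 1 to compound 2 (0.25 log units; within the scatter), which stayed within the scatter. Compound 4 is therefore estimated at 20000 nM.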

Compound 4, half-maximal inhibitory concentration: 10600 nM
Compound 4: middle estimate off by 1.9-fold (0.28 log units), on the high side, and the stated range covers the measured number.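

In this assay the swap of methyl for hydrogen on the aromatic ring gave a 1.5-fold lower number from compound 3 to compound 4 (0.17 log units; within the scatter) and so stays inside the usual spread of repeated measurements. The step printed for the earlier pair runs the other way, yet neither step nor the gap between them stands clear of that spread: the same change on two cores in this assay, a 1.8-fold higher number (0.25 log units; within the scatter) from compound 1 to compound 2 and a 1.5-fold lower number (0.17 log units; within the scatter) from compound 3 to compound 4, 2.6-fold (0.42 log units) apart, within the scatter of two such steps

These two pairs therefore give no sign that the change acts differently from one core to the other, but they do not prove that it acts alike, and a small real difference could be hidden in the scatter.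

The compounds shown leave open whether an ethyl group, a chlorine atom or a methoxy group in place of the methyl would move the number beyond the scatter. Also open, as far as these compounds go, is whether the swap would behave the same way with a carboxylic acid in place of the dimethylamino group at the end of the chain.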